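The compounds below may be only part of what the source reports. "The series", "measured", "known", "first", "only" and "open" are said of these compounds alone.

Compound 1 `CCOC(=O)c1[nH]c(-c2cccc(C#N)c2)nc1C`: > 30000 nM
Compound 2 `CCOCCOn1c(-c2cccc(C#N)c2)nc(C)c1C(=O)OCC`: 6250 nM

Within the data shown here, in a functional assay on a cell-free system (plasma, Oryctolagus cuniculus) for inhibition, with stated times of 5 min, 1 min and 6 min (on this read-out lower numbers stand for stronger inhibition and higher numbers for weaker inhibition), compound 2 gives 6250 nM, the only true number so far. The entry for compound 1, > 30000 nM, is a limit of the assay and not a number. Among the measured compounds shown here, the one measured step, an at least 4.8-fold lower number from compound 1 to compound 2 (0.68 log units; beyond the scatter), put 2-ethoxyethoxy in place of hydrogen on an aromatic nitrogen.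

Compound 3 `CCOC(=O)c1c(C)nc(-c2cccc(C#N)c2)n1OCC(N)=O` keeps a chain there but alters its end: carbamoyl in place of ethoxymethyl on a saturated chain carbon bound to an oxygen on an aromatic ring. In words, carbamoyl replaces ethoxymethyl on a saturated chain carbon bound to an oxygen on an aromatic ring. For the measured compounds named here, no measured step tests such a swap, so the estimate rests on compound 2 and its step of an at least 4.8-fold lower number from compound 1 to compound 2 (0.68 log units; beyond the scatter), which shows only what adding the whole chain did. The expected result is no change beyond the scatter, a 1.1-fold higher number from compound 2 to compound 3 (0.05 log units; within the scatter). Compound 3 is expected at about 7000 nM, with an estimated range of 1800 nM to 28000 nM.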

Compound 3, half-maximal inhibitory concentration: > 30000 nM
Compound 3: a limit, no number; the forecaster's own chance of this, stated with the estimate: 12%; middle value at least 4.2-fold (0.63 log units) from the limit.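

The chain on the aromatic nitrogen does not lower the number merely by being there, as its end also matters: in this assay, carbamoyl in place of ethoxymethyl gives an at least 4.8-fold higher number from compound 2 to compound 3 (0.68 log units; beyond the scatter). The entry for compound 3, > 30000 nM, is a limit and not a number. The step between compound 1 and compound 3 cannot be read, which leaves compound 2 as the only compound here with a true number: the limit of > 30000 nM in this assay, at which 2 of the 3 values shown sit.

Going from 2-ethoxyethoxy to carbamoylmethoxy changes the chain's length and its end together, so the compounds shown do not tell which of the two matters. A longer chain ending in carbamoyl, or a chain of the same length as carbamoylmethoxy ending in an amine or a carboxylic acid, would help to separate them.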